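The compounds below may be only part of what the source reports. "The series", "measured", "known", "first", "only" and "open" are said of these compounds alone.

Compound 1 `Clc1ccc(Cc2nn3c(Br)c(-c4ccc(Cl)cc4)nc3s2)cc1` and compound 2 `COc1ccc(-c2nc3sc(Cc4ccc(Cl)cc4)nn3c2Br)cc1` have been tested in an ADME assay on CCRF-CEM cells (Homo sapiens) for cytotoxicity, with a stated time of 72 h; on this read-out lower numbers stand for stronger inhibition and higher numbers for weaker inhibition. In this assay compound 1 reaches only a limit, > 250000 nM. Compound 2 gives 58000 nM. Compound 1 sits at the limit of > 250000 nM in this assay, at which 1 of the 2 values shown sits, so compound 2 stands as the only number shown. Among the compounds with values here, the step of an at least 4.3-fold lower number from compound 1 to compound 2 (0.63 log units; beyond the scatter) is the single measured change. Compound 3 `COc1ccc(-c2nc3sc(Cc4ccc(Cl)cc4)nn3c2SC#N)cc1` differs from compound 2 by cyanosulfanyl in place of bromo on an aromatic carbon. Within the data shown here, no measured step concerns that change, so the expectation rests on compound 2 alone. Compound 3 is therefore expected to give 40000 nM, between 8000 nM and 200000 nM. That estimate means an expected step of a 1.5-fold lower number from compound 2 to compound 3 (0.16 log units; within the scatter), within the scatter.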

Compound 3, half-maximal inhibitory concentration: 10000 nM
Estimate against measurement, compound 3: 4.0-fold (0.60 log units) above; measured number inside the range.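

In this assay, the place next to the ring atom that bears the 4-methoxyphenyl group proves able to move the read-out: cyanosulfanyl in place of bromo gives a 5.8-fold lower number from compound 2 to compound 3 (0.76 log units; beyond the scatter) on this core. Within the data shown here, the earlier step concerned only chloro and methoxy on an aromatic carbon, so this is the first measured change at this position. Nothing measured here accounts for this step.

Going by these compounds, whether an amine or methylsulfanyl at this place would give a similar number remains open. So does whether the change would hold with chloro in place of methoxy.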